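The compounds below may be only part of what the source reports. "The series", "measured", "known", "first", "only" and "open" are said of these compounds alone.

Measured so far in a functional assay on MCF7 cells (Homo sapiens), read by MTT assay, with a stated time of 48 h; a lower number here means a stronger inhibitor, a higher number a weaker inhibitor:
- compound 1 `CCn1c(C(=O)NCCN(C)C)ccc1C(CC)(CC)c1ccc(OCC(O)C(C)(C)C)c(C)c1`: 660 nM
- compound 2 `CCN(CC)CCCNC(=O)c1ccc(C(CC)(CC)c2ccc(OCC(O)C(C)(C)C)c(C)c2)n1CC`: 190 nM
- compound 3 `CCn1c(C(=O)NCC(OC)OC)ccc1C(CC)(CC)c1ccc(OCC(O)C(C)(C)C)c(C)c1`: > 50000 nM

The entry for compound 3 is a limit of the assay, not a number. It stands at the limit of > 50000 nM in this assay, at which 1 of the 3 values shown sits, so the size of any step starting from compound 3 is known only in part.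

Compound 4 `CCn1c(C(=O)NCCN)ccc1C(CC)(CC)c1ccc(OCC(O)C(C)(C)C)c(C)c1` keeps the shared core and changes only the end of the amide chain: aminomethyl in place of dimethoxymethyl on a saturated chain carbon bound to an amide-type nitrogen. That is, aminomethyl in place of dimethoxymethyl on a saturated chain carbon bound to an amide-type nitrogen, or 2,2-dimethoxyethyl to 2-aminoethyl when cut one bond further out.

For the measured compounds named here, two measured steps bear on this change, both running in the opposite direction: an at least 75-fold higher number from compound 1 to compound 3 (1.87 log units; beyond the scatter) and an at least 260-fold higher number from compound 2 to compound 3 (2.42 log units; beyond the scatter). Among these three compounds, the two with an amino-ended chain give numbers and the one with the dimethoxymethyl end gives only a limit. The step between the two amines is much smaller: a 3.5-fold lower number from compound 1 to compound 2 (0.54 log units; beyond the scatter). Going by the values given here, no measured compound carries the unsubstituted aminomethyl end, so the range has to stay wide.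

A large step to a lower number is expected in this assay. The estimated step is an at least 50-fold lower number from compound 3 to compound 4 (1.69 log units; beyond the scatter). For compound 4 the estimate is 1000 nM, with an expected range of 200 nM to 6000 nM.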

Compound 4, half-maximal inhibitory concentration: 5.9 nM
Beside the measured number, compound 4's estimate is 170-fold (2.23 log units) above it, and the stated range ends above it.
By their numbers in this assay, from the lowest: compound 4; then compound 2; then compound 1. At a limit, above all of these: compound 3.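

In this assay, the 2-aminoethyl chain of compound 4 shows that alkyl groups on the terminal nitrogen are not required for a low number, with a 110-fold lower number from compound 1 to compound 4 (2.05 log units; beyond the scatter) and a 32-fold lower number from compound 2 to compound 4 (1.51 log units; beyond the scatter). The earlier 3.5-fold lower number from compound 1 to compound 2 (0.54 log units; beyond the scatter) favoured the larger amine end, and compound 4 goes against that reading: the smallest amino end among these compounds carries the lowest number, so size alone does not order the amine series. Against the dimethoxymethyl end the change is an at least 8400-fold lower number from compound 3 to compound 4 (3.92 log units; beyond the scatter), and that size is only a bound, since the entry for compound 3 is a limit of the assay: the limit of > 50000 nM in this assay, at which 1 of the 4 values shown sits.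

A methylamino end, a hydroxyl end or a longer chain ending in an unsubstituted amino group would test whether the low number belongs specifically to the 2-aminoethyl chain. As far as these compounds go, with a single cell line in this assay, it also stays open whether this order holds in other cells, including non-cancerous ones, and whether it carries over to other cores.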